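Methyl on the phenyl ring: a repeated change

The source may hold more compounds than are shown below. What is called first, only, known or untested is meant among the compounds shown, and "the series" means these compounds.

Measured compounds in a functional assay on HT-29 cells (Homo sapiens) for cytotoxicity, read by MTT assay, with a stated time of 72 h; a higher number here means a weaker inhibitor, a lower number a stronger inhibitor:
compound 1 `O=C1N/C(=N/c2csc(-c3ccc(Cl)cc3)c2)S/C1=C\c1ccccc1` 10500 nM
compound 2 `Cc1ccc(/C=C2\S/C(=N\c3csc(-c4ccc(Cl)cc4)c3)NC2=O)cc1` 6400 nM
compound 3 `O=C1CS/C(=N\c2csc(-c3ccc(Cl)cc3)c2)N1c1ccccc1` 41400 nM

Compound 1 and compound 2 share a core and differ by methyl in place of hydrogen on an aromatic carbon. This gave a 1.6-fold lower number from compound 1 to compound 2 (0.22 log units; within the scatter), so the two values of this assay cannot be told apart. Compound 3 stands apart from compound 1: the difference between the two cores is not broken down here. Its value is the highest of the three, beyond the scatter from compound 1 and from compound 2.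

Compound 4 `Cc1ccc(N2C(=O)CS/C2=N\c2csc(-c3ccc(Cl)cc3)c2)cc1` is built from compound 3 by methyl in place of hydrogen on an aromatic carbon. The place of the change is described in the same words as for the pair of compound 1 and compound 2, so it is the same change on a different core. Going by the values given here, the one earlier measurement of this change, a 1.6-fold lower number from compound 1 to compound 2 (0.22 log units; within the scatter), lay within the scatter, and this is the only evidence at hand. Compound 4 is therefore expected to give 28000 nM in this assay, between 14000 nM and 60000 nM, a step of a 1.5-fold lower number from compound 3 to compound 4 (0.17 log units; within the scatter) that rests on the outcome for compound 2.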

Compound 4, half-maximal inhibitory concentration: 28900 nM
Compound 4: the middle estimate sits 1.0-fold (0.01 log units) below what was measured; measured number inside the range.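

In this assay the change from phenyl to 4-methylphenyl gave a 1.4-fold lower number from compound 3 to compound 4 (0.16 log units; within the scatter) and so matched what the same change did on the other core: the same change on two cores in this assay, a 1.6-fold lower number (0.22 log units; within the scatter) from compound 1 to compound 2 and a 1.4-fold lower number (0.16 log units; within the scatter) from compound 3 to compound 4, 1.1-fold (0.06 log units) apart, within the scatter of two such steps. On these two cores, then, methyl in place of hydrogen on an aromatic carbon left the values within the scatter each time, and that outcome carried over from one core to the other. This does not show that the change is without effect in general: two pairs in a single assay cannot separate a small real shift from scatter, and they say nothing about a core outside these two.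

The compounds shown leave open whether a different group at this place, such as an amine, a carboxylic acid or a longer chain, would give a step beyond the scatter. They also leave open whether such a group would act alike on both cores.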